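Nitro for Bromo on a Cytotoxicity Limit

This account rests on a few compounds, and the source may have more. Where it says the series, first, only, none or still open, it means among the compounds named here.

Compound 1 `Cc1cc(C)cc(S(=O)(=O)n2c(SCC(=O)Nc3ccccc3Br)nc3ccccc32)c1` was tested in an ADME assay on MT4 cells (Homo sapiens) for cytotoxicity; a lower number here means that less compound is tolerated, a higher number that more compound is tolerated. For compound 1 the result is a limit of the assay rather than a number, >= 235000 nM; this is the limit of >= 235000 nM in this assay, at which 1 of the 2 values shown sits. Among the measured compounds shown here, its only measured neighbour is compound 2 `Cc1cc(C)cc(S(=O)(=O)n2c(SCC(=O)Nc3ccccc3Br)nc3ccc(Cl)cc32)c1`; in this assay compound 2 gives 145000 nM. The step of an at least 1.6-fold lower number from compound 1 to compound 2 (0.20 log units; that floor lies within the scatter) stays within the scatter. Compound 3 `Cc1cc(C)cc(S(=O)(=O)n2c(SCC(=O)Nc3ccccc3[N+](=O)[O-])nc3ccccc32)c1` differs from compound 1 elsewhere: nitro in place of bromo on an aromatic carbon. No measured step touches this exchange, so the one step shown gives no direction for it. The expectation is therefore a move no larger than the scatter, an at least 1.1-fold lower number from compound 1 to compound 3 (0.07 log units; that floor lies within the scatter), with a fair chance that the assay again reports only a limit. Compound 3 is estimated at 200000 nM, within a range from 80000 nM to 300000 nM.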

Compound 3, half-maximal cytotoxic concentration: >= 26000 nM
Compound 3: a limit, no number; the forecaster's own chance of this, stated with the estimate: 50%; the middle value lies beyond the limit too.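

The step from compound 1 to compound 3, nitro in place of bromo, cannot be read: in this assay both compounds give only a limit of the assay, not a number. From the compounds shown here alone, whether this exchange shifts the tolerated concentration, and in which direction, remains open.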